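Lengthening the alkyl chain from compound 2 to compound 3

The source may report more compounds than this note shows. Statements on the series, on what has been measured and on what is new or still open speak of the compounds shown alone.

compound 1, `CCCCNc1ccc(C(=O)O)cc1S(N)(=O)=O`: 6.4%
compound 2, `CCCCCCNc1ccc(C(=O)O)cc1S(N)(=O)=O`: 4.9%

In an assay on HEK293 cells for inhibition of solute carrier family 12 member 2 (Homo sapiens), read by fluorescence, with a stated time of 30 min, tested at 100 uM (on this read-out higher numbers stand for a stronger effect at the one concentration tested and lower numbers for a weaker effect), compound 1 gives 6.4%, and compound 2 gives 4.9%. On the two numbers shown, compound 2 and compound 1 sit within the scatter of each other, the step of a number 1.5 percentage points lower from compound 1 to compound 2 (within the scatter) being too small to separate them. Compound 3, `CCCCCCCCNc1ccc(C(=O)O)cc1S(N)(=O)=O`, differs from compound 2 by ethyl in place of hydrogen on a saturated chain carbon, six bonds along the chain from a nitrogen on an aromatic ring. Among the compounds with values here, the only measured step that bears on this change is the one from compound 1 to compound 2, the same kind of extension two bonds nearer the nitrogen, which gave a number 1.5 percentage points lower from compound 1 to compound 2 (within the scatter). On that basis no step beyond the scatter is expected in this assay for compound 3, with an expected step of a number 0.4 percentage points lower from compound 2 to compound 3 (within the scatter). Compound 3 is therefore estimated at 4.5%, within a range from -3% to 13%.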

Compound 3, a percentage reported as inhibition, at one concentration (the size of the read-out at that concentration, not a potency): 24%
Beside the measured number, compound 3's estimate is 19.5 percentage points below it; the whole stated range lies below it.
By their numbers in this assay, from the lowest: compounds 2 and 1 (each within the scatter of the next); then compound 3.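

In this assay, ethyl in place of hydrogen six bonds along the chain from the nitrogen gives a number 19.1 percentage points higher from compound 2 to compound 3 (beyond the scatter), whereas the same replacement four bonds along gave a number 1.5 percentage points lower from compound 1 to compound 2 (within the scatter), so this kind of extension does not have the same effect at both places. The butyl change gives a number 17.6 percentage points higher from compound 1 to compound 3 (beyond the scatter), which places compound 3 clear of both shorter-chain compounds, but compound 2 goes against any steady rise with chain length across the three. Nothing shown here accounts for this jump.

On these data alone, whether a longer chain would raise the number further or lose the gain remains open, since three chain lengths cannot show where the trend ends. Also open, as far as these compounds go, is whether a chain carrying a hydroxyl group or an amine would keep the gain seen with compound 3.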